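Changing the Group on the Ring Nitrogen of Compound 2

The source may hold more compounds than are shown below. What is called first, only, known or untested is meant among the compounds shown, and "the series" means these compounds.

Three compounds have been measured in a functional assay on MGC-803 cells (Homo sapiens) for inhibition, read by MTT assay, with a stated time of 72 h; on this read-out lower numbers stand for stronger inhibition and higher numbers for weaker inhibition:

compound 1, `Fc1ccccc1Cn1cc(CSC(=S)N2CCNCC2)nn1`: 19400 nM
compound 2, `CC(C)(C)OC(=O)N1CCN(C(=S)SCc2cn(-c3ccccc3F)nn2)CC1`: 119000 nM
compound 3, `O=C(OCc1ccccc1)N1CCN(C(=S)SCc2cn(Cc3ccc(F)cc3)nn2)CC1`: 17600 nM

Compound 2 stands at the highest number of the three. Compound 1 is its nearest neighbour and compound 3 its furthest, and both gaps lie beyond the usual scatter, so compound 2 is the weakest of the measured set. No pair of these compounds differs in a single place, so no step between measured compounds can be read off directly.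

Compound 4, `COc1ccc(Cn2cc(CSC(=S)N3CCN(C(=O)OC(C)(C)C)CC3)nn2)cc1`, is not yet measured. It is derived from compound 2 by one change: 4-methoxybenzyl in place of 2-fluorophenyl on an aromatic nitrogen. The two compounds with lower numbers, compound 1 and compound 3, carry other groups on the same ring nitrogen but also differ from compound 2 elsewhere, so they guide the expectation only loosely. On that basis a downward step from compound 2 is expected, estimated as a 4.8-fold lower number from compound 2 to compound 4 (0.68 log units; beyond the scatter), with the size of the step uncertain. For compound 4 the expected value in this assay is 25000 nM, within a range from 8000 nM to 80000 nM.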

Compound 4, half-maximal inhibitory concentration: 22800 nM
For compound 4 the middle estimate is 1.1-fold (0.04 log units) above the measured one, and the stated range covers the measured number.
By their numbers in this assay, from the lowest: compounds 3, 1 and 4 (each within the scatter of the next); then compound 2.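

In this assay, among these compounds, putting 4-methoxybenzyl in place of 2-fluorophenyl on the aromatic nitrogen gives a 5.2-fold lower number from compound 2 to compound 4 (0.72 log units; beyond the scatter) with the rest of the molecule unchanged, which is the first step read at a single place. Among the compounds shown here, it shows that the group on this nitrogen alone can move the number beyond the scatter, something the earlier compounds could suggest only loosely since they also differ elsewhere. Nothing shown here explains the step.

The change replaces a directly attached ring with a benzyl group and swaps fluorine for methoxy at once, so the compounds shown cannot say which of these matters. As far as these compounds go, whether 4-methoxyphenyl attached directly to this nitrogen, or plain benzyl, would behave like compound 2 or compound 4 remains open.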